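An Ether Side Chain Gives Way to a Ketone Ring

A few compounds are considered here, and "the series" means these few. Any claim that something is new, unique, unknown or untested is made for them only; others in the source may bear on it.

Of the compounds shown here, two have been measured in an assay on isolated protein for inhibition of serine/threonine-protein kinase PAK 4 (Homo sapiens); a lower number here means a stronger inhibitor, a higher number a weaker inhibitor. Compound 1 `CN1CC(C)(C)C(c2cc(Nc3ccnc(N(C)C[C@H]4CC[C@H](N)CC4)n3)n[nH]2)C1=O` reaches only a limit of the assay, > 2900 nM. Compound 2 `COCC(C)c1cc(Nc2ccnc(N(C)Cc3ccc4[nH]cnc4c3Cl)n2)n[nH]1` gives 617 nM in this assay, the only true number among the two shown; the other value is the limit of > 2900 nM in this assay, at which 1 of the 2 values shown sits. Compound 3 `CN(Cc1ccc2[nH]cnc2c1Cl)c1nccc(Nc2cc(C3CCC(=O)C3)[nH]n2)n1` differs from compound 2 in one place: 3-oxocyclopentyl in place of 1-(methoxymethyl)ethyl on an aromatic carbon. Within the data shown here, no measured pair of compounds shows such a change, so there is no yardstick for its size. The account therefore expects a 1.1-fold higher number from compound 2 to compound 3 (0.05 log units; within the scatter), a step that is not anticipated to lie clearly beyond the scatter in either direction. On that basis the inhibition constant of compound 3 is estimated at 700 nM, with a range from 200 nM to 2500 nM.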

Compound 3, inhibition constant: 629 nM
Beside the measured number, compound 3's estimate is 1.1-fold (0.05 log units) above it, within the range that was stated.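

In this assay, among these compounds, the exchange of 1-(methoxymethyl)ethyl for 3-oxocyclopentyl gives a 1.0-fold higher number from compound 2 to compound 3 (0.01 log units; within the scatter) and is the first step between measured compounds that differ in one place. It shows that, on this aromatic carbon of the five-membered aromatic ring with 2 nitrogen, an open group with no ring and a five-membered non-aromatic ring of carbon only give values within the scatter of each other. Nothing measured here bears on why the two groups read alike.

Both groups carry one oxygen, so the compounds shown leave open whether a plain cyclopentyl group, without the carbonyl, would read the same. They also leave open whether an amine or a carboxylic acid at this position would move the number beyond the scatter.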